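The compounds below may be only part of what the source reports. "The series", "measured", "known", "first", "only" and "open" are said of these compounds alone.

Measured so far in a functional assay on NCI-H460 cells (Homo sapiens) for inhibition, read by sulforhodamine B assay, with a stated time of 48 h; on this read-out lower numbers stand for stronger inhibition of growth and higher numbers for weaker inhibition of growth:
compound 1 `COC(=O)c1sc2cc(Nc3ccc(OC)cc3)cnc2c1N`, 95000 nM
compound 2 `COC(=O)c1sc2cc(Nc3ccc(OC)cc3OC)cnc2c1N`, 26300 nM

Compound 1 stands highest of the two numbers; its nearest neighbour is compound 2, with a 3.6-fold lower number from compound 1 to compound 2 (0.56 log units; beyond the scatter). The step to compound 3 `COC(=O)c1sc2cc(Nc3ccc(OC)c(OC)c3)cnc2c1N` is methoxy in place of hydrogen on an aromatic carbon. Among the measured compounds shown here, the only step that bears on it is the one from compound 1 to compound 2, a change of the same kind at a different place on the same ring, which was beyond the scatter in the lowering direction. A step of similar kind but uncertain size is therefore expected for compound 3, a 2.1-fold lower number from compound 1 to compound 3 (0.32 log units; beyond the scatter). Compound 3 is estimated at 45000 nM, range 15000 nM to 130000 nM.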

Compound 3, concentration for 50% growth inhibition: 26200 nM
Estimate against measurement, compound 3: 1.7-fold (0.23 log units) above; the measured number falls inside the stated range.
By their numbers in this assay, from the lowest: compounds 3 and 2 (each within the scatter of the next); then compound 1.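

In this assay, methoxy in place of hydrogen on the aromatic carbon ortho to a methoxy group and meta to a large group gives a 3.6-fold lower number from compound 1 to compound 3 (0.56 log units; beyond the scatter). That step matches a 3.6-fold lower number from compound 1 to compound 2 (0.56 log units; beyond the scatter) in size, so the lowering is not tied to a single place on this ring, and compound 2 and compound 3 lie within the scatter of each other. No available evidence explains this lowering. As far as these compounds go, whether an ethoxy group, a hydroxyl group or an amine at this carbon would give a similar step remains open.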